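Anilino series: fluoro on the phenyl ring

The source may hold more compounds than are shown below. What is called first, only, known or untested is meant among the compounds shown, and "the series" means these compounds.

Compound 1 `CCCCNc1cccc(NC(=O)c2ccc(OCCC)cc2)n1` carries a butyl chain on the ring nitrogen; in an in vitro assay on HEK-tsA201 cells for antagonist activity at Neuronal acetylcholine receptor; alpha4/beta2 (Homo sapiens), read by fluorescence and calcium flux (a lower number here means a stronger inhibitor, a higher number a weaker inhibitor), compound 1 gives 54100 nM. Compound 2 `CCCOc1ccc(C(=O)Nc2cccc(Nc3ccccc3)n2)cc1` carries phenyl in place of that butyl. In this assay compound 2 reaches only > 100000 nM, which is a limit of the assay and not a number. The measured change is an at least 1.8-fold higher number from compound 1 to compound 2 (0.26 log units; that floor lies within the scatter), and one of the two values sits at the limit of > 100000 nM in this assay, at which 1 of the 2 values shown sits.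

Compound 3 `CCCOc1ccc(C(=O)Nc2cccc(Nc3ccccc3F)n2)cc1` differs from compound 2 by fluoro in place of hydrogen on an aromatic carbon, ortho to a large group. Going by the values given here, no measured step covers a fluoro for hydrogen exchange on this phenyl; the only measured step, an at least 1.8-fold higher number from compound 1 to compound 2 (0.26 log units; that floor lies within the scatter), concerns the group on the nitrogen and already ends at the limit. With compound 2 at the limit, a single fluoro has no measured basis to read as a step in either direction beyond the scatter. Compound 3 is therefore expected to stay near the limit of this assay, with an expected step of a number no higher from compound 2 to compound 3 (the limit leaves the size open). The estimate for compound 3 in this assay is 100000 nM, ranging from 30000 nM to 300000 nM.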

Compound 3, half-maximal inhibitory concentration: > 100000 nM
Compound 3 ended at the assay's limit; the forecaster's own chance of this, stated with the estimate: 70%; the middle value sits exactly at the limit.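

In this assay compound 3 gives > 100000 nM, which is a limit of the assay and not a number. The fluoro for hydrogen exchange on the anilino phenyl, ortho to a large group, therefore leaves the series where it was, and the step between the two limits cannot be read in size or in direction: the limit of > 100000 nM in this assay, at which 2 of the 3 values shown sit.

Set against the butyl chain on the nitrogen, 2-fluorophenyl gives an at least 1.8-fold higher number from compound 1 to compound 3 (0.26 log units; that floor lies within the scatter), so this aryl group, like the unsubstituted phenyl, is not shown to differ from butyl beyond the scatter.

Still open, on these data alone, is whether any group on this phenyl returns a readable value, for instance a methoxy or an amine in place of the fluoro, or a fluoro elsewhere on the ring. Also open, as far as these compounds go, is whether a chain longer than butyl, or a cyclohexyl, on the nitrogen gives a lower number than compound 1, at 54100 nM.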